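The source may hold more compounds than are shown below. What is called first, only, known or untested is meant among the compounds shown, and "the series" means these compounds.

Compound 2 `Cc1nn(-c2ccccc2)cc1/C=N/Nc1nc(Nc2ccccc2)nc(Nc2ccc(S(N)(=O)=O)cc2)n1` is a hydrazone of a shared core; in a functional assay on SNB-75 cells (Homo sapiens) for inhibition, read by sulforhodamine B assay, with a stated time of 48 h (on this read-out higher numbers stand for weaker inhibition of growth and lower numbers for stronger inhibition of growth), compound 2 gives 2690 nM. On the numbers shown it sits alongside compound 1 `NS(=O)(=O)c1ccc(Nc2nc(N/N=C/c3ccc(C(F)(F)F)cc3)nc(Nc3ccccc3)n2)cc1`, which in this assay gives 2050 nM, the step of a 1.3-fold higher number from compound 1 to compound 2 (0.12 log units; within the scatter) being within the scatter. Compound 3 `NS(=O)(=O)c1ccc(Nc2nc(N/N=C/c3ccccn3)nc(Nc3ccccc3)n2)cc1` differs from compound 2 by pyridin-2-yl in place of 3-methyl-1-phenyl-1H-pyrazol-4-yl on a carbon with a double bond to nitrogen. Within the data shown here, only the step from compound 1 to compound 2 bears on this change, and it was within the scatter, so no step beyond the scatter is expected in this assay: compound 3 is estimated at 2500 nM, between 1000 nM and 7000 nM, a step of a 1.1-fold lower number from compound 2 to compound 3 (0.03 log units; within the scatter).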

Compound 3, concentration for 50% growth inhibition: 1320 nM
Estimate against measurement, compound 3: 1.9-fold (0.28 log units) above, within the range that was stated.
By their numbers in this assay, from the lowest: compounds 3, 1 and 2 (each within the scatter of the next, the first and the last beyond it).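

In this assay, the place on a carbon with a double bond to nitrogen shows its first step beyond the scatter: pyridin-2-yl in place of 3-methyl-1-phenyl-1H-pyrazol-4-yl gives a modest change (a 2.0-fold lower number from compound 2 to compound 3 (0.31 log units; beyond the scatter)). Among these compounds, the same group in place of 4-(trifluoromethyl)phenyl stays within the scatter (a 1.6-fold lower number from compound 1 to compound 3 (0.19 log units; within the scatter)), so pyridin-2-yl is separated from only one of the two groups it replaces. No measurement shown accounts for this difference.

From the compounds shown here alone, whether a carboxylic acid, an amine or a longer alkyl chain at this place would move the number further remains open. Three compounds in one assay establish no trend.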